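The source may report more compounds than this note shows. Statements on the series, on what has been measured and on what is new or still open speak of the compounds shown alone.

Three compounds of a shared sulfonamide-acetamide core have been run through a functional assay on SH-SY5Y cells (Homo sapiens), read by MTT assay, with a stated time of 24 h; on this read-out higher numbers stand for an effect only at larger amounts of compound and lower numbers for an effect already at smaller amounts. Compound 1, `COc1ccc(NC(=O)CN(c2cc(Cl)ccc2OC)S(=O)(=O)c2ccccc2)cc1OC`, reaches only the limit of the assay, > 20000 nM. Compound 2, `CCN(CC)C(=O)CN(c1cc(Cl)ccc1OC)S(=O)(=O)c1ccccc1`, likewise stops at a limit, > 20000 nM. Compound 3, `COc1ccc(Cl)cc1N(CC(=O)N(C1CCCCC1)C1CCCCC1)S(=O)(=O)c1ccccc1`, gives 14300 nM. Going by the values given here, the one step between compounds differing in a single place, a step that the two limits leave unreadable from compound 1 to compound 2, cannot be sized, since it runs between two limits. Compound 4, `COc1ccc(Cl)cc1N(CC(=O)Nc1ccc([N+](=O)[O-])cc1)S(=O)(=O)c1ccccc1`, carries (4-nitrophenyl)amino in place of diethylamino on a carbonyl carbon. Among the compounds with values here, the only step that bears on this change is the unreadable one above, and the only evidence is the limit of > 20000 nM in this assay, at which 2 of the 3 values shown sit, so no direction beyond the scatter can be predicted for a number no higher from compound 2 to compound 4 (the limit leaves the size open). Compound 4 is therefore expected to sit around 20000 nM, between 8000 nM and 60000 nM, quite possibly again at a limit.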

Compound 4, half-maximal effective concentration: 8210 nM
Compound 4: middle estimate off by 2.4-fold (0.39 log units), on the high side; the range from low to high includes it.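

In this assay the position on the carbonyl carbon proves responsive, with an at least 2.4-fold lower number from compound 2 to compound 4 (0.38 log units; beyond the scatter). Compound 1 also carries an aromatic ring there, yet 4-nitrophenyl in place of 3,4-dimethoxyphenyl gives an at least 2.4-fold lower number from compound 1 to compound 4 (0.38 log units; beyond the scatter), so the ring alone does not decide the outcome. Both steps are only lower bounds, because each starts from a limit: the limit of > 20000 nM in this assay, at which 2 of the 4 values shown sit.

As far as these compounds go, how much of the change belongs to the nitro group remains open. A plain phenyl or a 4-aminophenyl on the same nitrogen would separate its share from that of the ring.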